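This account rests on a few compounds, and the source may have more. Where it says the series, first, only, none or still open, it means among the compounds named here.

Measured compounds:
- compound 1 `Cc1cccc(CNc2ncnc3c2ncn3[C@@H]2O[C@H](CO)[C@@H](O)[C@H]2O)c1` gives 6400 nM in a functional assay on HL-60 cells (Homo sapiens) for antiproliferative activity, with a stated time of 72 h; on this read-out higher numbers stand for weaker inhibition and lower numbers for stronger inhibition
- compound 2 `COc1cccc(CNc2ncnc3c2ncn3[C@@H]2O[C@H](CO)[C@@H](O)[C@H]2O)c1` gives 4900 nM in this assay

Compound 2 holds the lower of the two numbers, but the step of a 1.3-fold lower number from compound 1 to compound 2 (0.12 log units; within the scatter) falls within the scatter, so the two compounds cannot be told apart on this read-out. Compound 3 `OC[C@H]1O[C@@H](n2cnc3c(NCc4ccc(F)c(F)c4F)ncnc32)[C@H](O)[C@@H]1O` differs from compound 2 by 2,3,4-trifluorophenyl in place of 3-methoxyphenyl on a saturated chain carbon bound to a nitrogen on an aromatic ring. For the measured compounds named here, the only step measured so far, a 1.3-fold lower number from compound 1 to compound 2 (0.12 log units; within the scatter), also swaps one group on the phenyl ring for another, and it produced no change beyond the scatter. Going by the values given here, no measured step involves fluorine, so the effect of the entering 2,3,4-trifluorophenyl is unknown, and the single step available suggests that changes on this ring may matter little. Compound 3 is therefore expected to stay close to compound 2, with an estimated step of a 1.0-fold higher number from compound 2 to compound 3 (0.01 log units; within the scatter). The estimate for compound 3 is 5000 nM, within a range from 1500 nM to 16000 nM.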

Compound 3, half-maximal inhibitory concentration: 13000 nM
The estimate for compound 3 lay 2.6-fold (0.41 log units) below the measured number, and the stated range covers the measured number.
By their numbers in this assay, from the lowest: compounds 2 and 1 (each within the scatter of the next); then compound 3.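

In this assay, the group on the saturated chain carbon bound to a nitrogen on an aromatic ring can change the result after all: 2,3,4-trifluorophenyl in place of 3-methoxyphenyl gives a 2.7-fold higher number from compound 2 to compound 3 (0.42 log units; beyond the scatter), and in place of 3-methylphenyl it gives a 2.0-fold higher number from compound 1 to compound 3 (0.31 log units; beyond the scatter). Both steps lie beyond the scatter, unlike the earlier swap between the methyl and methoxy groups, and both are modest moves towards weaker inhibition. No supporting data are available to explain this loss.

The fluorines enter together and the methyl or methoxy group leaves in the same step, so these compounds cannot show which part of the change matters. Also open, on these data alone, is how the number would respond to a phenyl ring carrying a single fluorine, an amine or a carboxylic acid, or to a longer chain in this place.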